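The source may hold more compounds than are shown below. What is called first, only, known or untested is meant among the compounds shown, and "the series" means these compounds.

Measured compounds:
compound 1 `O=C(Nc1ccc(Oc2ccncc2-c2cccnc2)c(F)c1)c1nn(-c2cccc(F)c2)c(=O)c2ccccc12`, in a functional assay on MKN-45 cells (Homo sapiens) for cytotoxicity, read by MTT assay, with a stated time of 72 h (a higher number here means a weaker inhibitor, a lower number a stronger inhibitor), compound 1 gives 27 nM
compound 2 `Cn1cc(-c2ccccc2)cc(C(=O)Nc2ccc(Oc3ccncc3-c3cccnc3)c(F)c2)c1=O`, in this assay compound 2 gives 5400 nM

Compound 2 stands at the higher of the two numbers; compound 1 sits far lower, a gap beyond the scatter. Compound 3 `Cn1cc(-c2ccc(F)cc2)cc(C(=O)Nc2ccc(Oc3ccncc3-c3cccnc3)c(F)c2)c1=O` differs from compound 2 by fluoro in place of hydrogen on an aromatic carbon. Within the data shown here, no measured pair shows this change, so no step beyond the scatter is expected in either direction, and the estimated step of a 1.2-fold lower number from compound 2 to compound 3 (0.08 log units; within the scatter) is small. Compound 3 is expected at 4500 nM, within 1800 nM to 12000 nM.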

Compound 3, half-maximal inhibitory concentration: 7100 nM
Compound 3: the middle estimate sits 1.6-fold (0.20 log units) below what was measured; the range from low to high includes it.
By their numbers in this assay, from the lowest: compound 1; then compounds 2 and 3 (each within the scatter of the next).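

In this assay, among these compounds, the change from phenyl to 4-fluorophenyl gives a 1.3-fold higher number from compound 2 to compound 3 (0.12 log units; within the scatter) as the only single-place step. Fluoro in place of hydrogen at this aromatic carbon, para to a large group, therefore does not separate the two compounds. Nothing measured here bears on why this is so.

Going by these compounds, whether an amine, a methoxy group or a carboxylic acid at this position would give a step beyond the scatter stays open. Compound 1 differs from compounds 2 and 3 in more than one place, so its far lower number cannot be assigned to any single change.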